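Adding a second chloro to the weakest of three analogues

The source may hold more compounds than are shown below. What is called first, only, known or untested is meant among the compounds shown, and "the series" means these compounds.

Compound 1 `O=C(O)CCC/C=C1\C[C@H]2CC[C@H](/C=N/NC(=O)Nc3cccc(Cl)c3)[C@H]2C1` is the weakest of the three compounds measured in a functional assay on a cell-free system (plasma) for agonist activity at thromboxane A2 receptor (Homo sapiens); on this read-out lower numbers stand for stronger inhibition and higher numbers for weaker inhibition: it gives 6500 nM. Going by the values given here, compound 2 `O=C(O)CC/C=C1/C[C@H]2C[C@@H](O)[C@H](/C=N/NC(=O)Nc3cccc(Cl)c3)[C@H]2C1` gives 600 nM in this assay, and compound 3 `O=C(O)CCC/C=C1/C[C@H]2C[C@@H](O)[C@H](/C=N/NC(=O)Nc3ccccc3)[C@H]2C1` gives 100 nM; both numbers lie well below that of compound 1, beyond the usual scatter, and no single-point steps link these three structures.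

Compound 4 `O=C(O)CCC/C=C1\C[C@H]2CC[C@H](/C=N/NC(=O)Nc3ccc(Cl)c(Cl)c3)[C@H]2C1` is the unmeasured partner of compound 1. The change is chloro in place of hydrogen on an aromatic carbon. Among the compounds with values here, nothing in the measured set shows a second chloro on this phenyl ring, so there is no step to lean on; compounds 2 and 3 differ from compound 1 in more than one place and tell nothing about this substitution alone.

The expectation is a small lowering of the number from compound 1 to compound 4, roughly at the edge of the scatter, a 1.9-fold lower number from compound 1 to compound 4 (0.27 log units; within the scatter). Compound 4 is therefore estimated at 3500 nM, within a range from 1200 nM to 10000 nM.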

Compound 4, half-maximal inhibitory concentration: 9000 nM
Beside the measured number, compound 4's estimate is 2.6-fold (0.41 log units) below it; the range from low to high includes it.
By their numbers in this assay, from the lowest: compound 3; then compound 2; then compounds 1 and 4 (each within the scatter of the next).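

Chloro in place of hydrogen on this aromatic carbon, ortho to a chloro group and para to a large group, gives a 1.4-fold higher number from compound 1 to compound 4 (0.14 log units; within the scatter) in this assay and so does not separate the two compounds. Going by these compounds alone, this is the first direct reading of the change from 3-chlorophenyl to 3,4-dichlorophenyl, which the earlier compounds could not give, as each differs from compound 1 in more than one place. Nothing measured here offers an explanation for this result.

As far as these compounds go, whether a methoxy group, an amine or a carboxylic acid on this aromatic carbon would move the number beyond the scatter remains open. From the compounds shown here alone, it is also open whether a second chloro would read the same way on the core of compound 2.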